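The compounds below may be only part of what the source reports. "The series", "measured", "known", "first", "only" and "open" are said of these compounds alone.

Measured compounds in a toxicity assay on A549 cells (Homo sapiens) for cytotoxicity, read by luminescence and CellTiter-Glo, with a stated time of 48 h; on this read-out higher numbers stand for lower toxicity in this test and lower numbers for higher toxicity in this test:
Compound 1 `CCCCOc1ccc(-c2nc3ncccn3c2NC(C)C)cc1` gives 68000 nM.
Compound 2 `CCCCOc1ccc(-c2nc3ncccn3c2NCC2CC2)cc1` gives only a limit of the assay, > 100000 nM.
Compound 3 `CCCCOc1ccc(-c2nc3ncccn3c2N)cc1` gives only a limit of the assay, > 100000 nM.

Going by the values given here, compound 1 thus stands as the only numerical value in this assay, the other two compounds sitting at the limit of > 100000 nM in this assay, at which 2 of the 3 values shown sit. Compound 4 `CCCCOc1ccc(-c2nc3ncccn3c2NCc2ccccn2)cc1` differs from compound 1 by (pyridin-2-yl)methyl in place of isopropyl on a nitrogen on an aromatic ring. Among the compounds with values here, the steps that bear on this change are an at least 1.4-fold higher number from compound 1 to compound 2 (0.16 log units; that floor lies within the scatter) and an at least 1.4-fold higher number from compound 1 to compound 3 (0.16 log units; that floor lies within the scatter); both floors lie within the scatter, so neither shows a clear shift. Compound 4 is therefore expected to show a 1.5-fold higher number from compound 1 to compound 4 (0.17 log units; within the scatter), most likely ending at a limit again. The estimate for compound 4 is 100000 nM, with a range from 40000 nM to 300000 nM.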

Compound 4, half-maximal cytotoxic concentration: > 100000 nM
Compound 4: no number, only a limit (the forecaster's own chance of this, stated with the estimate: 65%); the middle value lies on the limit itself.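

Going by these compounds alone, compound 4 joins compound 2 and compound 3 in giving a limit rather than a number, so compound 1 remains the only compound with a numerical value in this assay: the limit of > 100000 nM in this assay, at which 3 of the 4 values shown sit. With a six-membered aromatic ring and a hydrogen-bond acceptor entering on the nitrogen, the change gives an at least 1.4-fold higher number from compound 1 to compound 4 (0.16 log units; that floor lies within the scatter), so it shows no clear shift. The steps to compound 4 from compound 2 and compound 3 cannot be read.

Where these three compounds lie beyond the limit remains open. So does whether a longer alkyl chain or a carboxylic acid on this nitrogen would give a number.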